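Dopamine transporter inhibition: a thiophene replaces a thiadiazole

The compounds below may be only part of what the source reports. "The series", "measured", "known", "first", "only" and "open" are said of these compounds alone.

Compound 1 `[O-][S+](Cc1ccc(Cl)s1)C(c1ccccc1)c1ccccc1`: 12800 nM
Compound 2 `CC(C)c1nnsc1C[S+]([O-])C(c1ccccc1)c1ccccc1`: 69100 nM

Of the compounds shown here, two sharing the same core have been measured in an assay on HEK293 cells for inhibition of sodium-dependent dopamine transporter (Homo sapiens), read by scintillation counting, with stated times of 5 min and 1 min; on this read-out lower numbers stand for stronger inhibition and higher numbers for weaker inhibition. Compound 1 gives 12800 nM, while compound 2 gives 69100 nM, and the step of a 5.4-fold higher number from compound 1 to compound 2 (0.73 log units; beyond the scatter). Among the compounds with values here, compound 2 therefore stands with the highest, that is the weakest, number of the two, its only neighbour being compound 1.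

Compound 3 `Cc1scc(C[S+]([O-])C(c2ccccc2)c2ccccc2)c1C` has not yet been measured. It differs from compound 2 in one place: 4,5-dimethylthiophen-3-yl in place of 4-isopropyl-1,2,3-thiadiazol-5-yl on a saturated chain carbon bound to a sulfur. Within the data shown here, the only measured step that bears on this change is the one from compound 1 to compound 2, in which a thiophene ring gave way to a thiadiazole ring and the number rose modestly beyond the scatter. Compound 3 reverses that ring exchange, though with different substituents on the thiophene, so a partial return toward the number of compound 1 is expected rather than a full one. Compound 3 is thus estimated to come in lower than compound 2, with the expected step of a 2.8-fold lower number from compound 2 to compound 3 (0.44 log units; beyond the scatter). The estimate for compound 3 in this assay is 25000 nM, within a range from 8000 nM to 80000 nM.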

Compound 3, half-maximal inhibitory concentration: 284000 nM
Compound 3: middle estimate off by 11-fold (1.06 log units), on the low side; measured number outside the range, above it.
By their numbers in this assay, from the lowest: compound 1; then compound 2; then compound 3.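

In this assay the exchange of the ring on a saturated chain carbon bound to a sulfur gives a 4.1-fold higher number from compound 2 to compound 3 (0.61 log units; beyond the scatter) and so shows that a thiophene in place of the thiadiazole does not by itself bring the number back toward that of compound 1. The two thiophene groups are far from interchangeable at this place: 4,5-dimethylthiophen-3-yl in place of 5-chlorothiophen-2-yl gives a 22-fold higher number from compound 1 to compound 3 (1.35 log units; beyond the scatter) and is the largest step among these compounds, leaving compound 3 as the weakest of the three and showing that the ring type alone does not set the number here. Nothing in the material shown offers an explanation for either step.

On these data alone, what remains open is how much of the gap between the two thiophene groups belongs to the chlorine, to the two methyl groups or to the way the ring is attached, since these differ together between compound 1 and compound 3. The compounds shown also leave open how the number would respond to an amine, a carboxylic acid or a longer chain at this same place on the shared core.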